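Neopentyl to difluorophenyl on the imidazole-borne chain carbon

The source may report more compounds than this note shows. Statements on the series, on what has been measured and on what is new or still open speak of the compounds shown alone.

Compound 1 `CC(C)(C)Cc1cnc(CCc2ccc(-c3ccccc3C(=O)O)cc2)[nH]1` gives 106 nM in an in vitro functional assay on cells for agonist activity at Bombesin receptor subtype-3 (Homo sapiens), read by luminescence and calcium flux; on this read-out lower numbers stand for an effect already at smaller amounts and higher numbers for an effect only at larger amounts of compound.
Compound 2 `O=C(O)c1ccccc1-c1ccc(CCc2ncc(CC3CC3)[nH]2)cc1` gives 1000 nM in this assay.
Compound 3 `CC(C)(C)CCc1cnc(CCc2ccc(-c3ccccc3C(=O)O)cc2)[nH]1` gives 39 nM in this assay.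

Compound 3 has the lowest number of the three measured compounds; the step of a 2.7-fold lower number from compound 1 to compound 3 (0.43 log units; beyond the scatter) separates it from compound 1, and the step of a 26-fold lower number from compound 2 to compound 3 (1.41 log units; beyond the scatter) from compound 2. Compound 4 `O=C(O)c1ccccc1-c1ccc(CCc2ncc(Cc3cccc(F)c3F)[nH]2)cc1` differs from compound 3 by 2,3-difluorophenyl in place of neopentyl on a saturated chain carbon bound to an aromatic carbon.

The measured steps all change the same group on the same saturated chain carbon: a 9.4-fold higher number from compound 1 to compound 2 (0.97 log units; beyond the scatter), a 2.7-fold lower number from compound 1 to compound 3 (0.43 log units; beyond the scatter) and a 26-fold lower number from compound 2 to compound 3 (1.41 log units; beyond the scatter). They show that this position is sensitive and that a smaller, ring-bearing group gave the highest number, while the larger open chains gave the lower numbers. For the measured compounds named here, the entering 2,3-difluorophenyl is an aromatic ring, larger than any of the three measured groups, so none of the measured steps covers it directly. A modest step to a higher number is expected, as a 2.8-fold higher number from compound 3 to compound 4 (0.45 log units; beyond the scatter). Compound 4 is therefore estimated at 110 nM in this assay, within the range 25 nM to 600 nM.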

Compound 4, half-maximal effective concentration: 87 nM
For compound 4 the middle estimate is 1.3-fold (0.10 log units) above the measured one; the range from low to high includes it.
By their numbers in this assay, from the lowest: compound 3; then compounds 4 and 1 (each within the scatter of the next); then compound 2.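

With 2,3-difluorophenyl in place of neopentyl on this saturated chain carbon bound to an aromatic carbon, this assay gives a 2.2-fold higher number from compound 3 to compound 4 (0.35 log units; beyond the scatter) as a modest cost, so an aromatic ring can sit at this position without the large loss seen for compound 2. The change to 2,3-difluorophenyl from cyclopropyl gives an 11-fold lower number from compound 2 to compound 4 (1.06 log units; beyond the scatter) and is large, so compound 2 does not set a trend for ring-bearing groups here. Against tert-butyl, the change gives a 1.2-fold lower number from compound 1 to compound 4 (0.09 log units; within the scatter) and separates nothing, so an open chain and this aromatic ring serve about equally in this pair. Nothing shown here explains these differences.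

The compounds shown leave open what the two fluorine atoms contribute, a question that an unsubstituted phenyl at this carbon would address. They also leave open how an amine or a hydroxyl group on this chain would read out.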